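A few compounds are considered here, and "the series" means these few. Any claim that something is new, unique, unknown or untested is made for them only; others in the source may bear on it.

Going by the values given here, in a functional assay on cells (CNS carcinoma cell, Homo sapiens) for cytotoxicity, read by sulforhodamine B assay, with a stated time of 48 h (on this read-out higher numbers stand for weaker inhibition of growth and lower numbers for stronger inhibition of growth), three compounds have numbers so far: compound 1 `COc1cc2c(cc1C)NC(=O)/C2=C/c1c(OC)nc2sc(C)cn12` gives 5700 nM, compound 2 `O=C1Nc2ccccc2C1=Cc1c(-c2ccncc2)nc2sccn12` gives 1600 nM, and compound 3 `COc1ccc2c(c1)/C(=C\c1c(OC)nc3sc(C)cn13)C(=O)N2` gives 430 nM. Compound 3 therefore has the lowest number of the three, and its gaps to the other two lie beyond the usual scatter.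

Compound 4 `COc1nc2sc(C)cn2c1/C=C1/C(=O)Nc2ccc(O)cc21` has not been measured yet. It differs from compound 3 in one place: hydrogen in place of methyl on an oxygen on an aromatic ring. This is a change from methoxy to hydroxy, with hydrogen in place of methyl on an oxygen on an aromatic ring.

Among the compounds with values here, only one measured step bears on this change, and only loosely. It is a 13-fold lower number from compound 1 to compound 3 (1.12 log units; beyond the scatter), a large step beyond the scatter. There, however, hydrogen replaces methyl on an aromatic carbon, not on an oxygen. It shows that losing one methyl can matter a great deal among these compounds, but its size and direction cannot simply be carried over. Within the data shown here, no measured pair shows the change from methoxy to hydroxy itself.

With so little to go on, a small step in this assay is the cautious expectation, leaning towards a higher number, and it may not clear the scatter. The expected change is a 1.6-fold higher number from compound 3 to compound 4 (0.21 log units; within the scatter). For compound 4 the estimated value is 700 nM, with an expected range from 150 nM to 3000 nM.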

Compound 4, concentration for 50% growth inhibition: 4760 nM
Compound 4: the middle estimate sits 6.8-fold (0.83 log units) below what was measured; measured number outside the range, above it.
By their numbers in this assay, from the lowest: compound 3; then compound 2; then compounds 4 and 1 (each within the scatter of the next).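

In this assay the methoxy group of compound 3 matters: changing it to hydroxy gives an 11-fold higher number from compound 3 to compound 4 (1.04 log units; beyond the scatter) and so takes away most of what set compound 3 apart from the others. The only earlier step that removed a methyl, a 13-fold lower number from compound 1 to compound 3 (1.12 log units; beyond the scatter), was on an aromatic carbon and went the opposite way, so among these compounds the loss of one methyl can shift the number up or down depending on where it happens. Nothing available on these compounds accounts for the rise seen with hydroxy.

From the compounds shown here alone, it remains open whether a longer chain on the same oxygen, such as ethoxy, would hold the number near that of compound 3, or whether a different group in place of the methoxy, such as an amine or a fluorine, would do the same. Going by these compounds alone, also open is whether the change from methoxy to hydroxy would give a step of similar size and direction in compounds that differ elsewhere in the structure, since only this one pair shows it.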